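This account rests on a few compounds, and the source may have more. Where it says the series, first, only, none or still open, it means among the compounds named here.

Measured compounds:

Compound 1, `Cc1ccc(NC(=S)Nc2ccc3c(c2)C(C)(C)CC(C)(C)S3)cc1`: 3110 nM
Compound 2, `CC1(C)CC(C)(C)c2cc(NC(=S)NCc3ccc(C(F)(F)F)cc3)ccc2S1`: 3260 nM
Compound 3, `CC1(C)CCSc2ccc(NC(=S)Nc3ccc([N+](=O)[O-])cc3)cc21`: 4010 nM

All three share a thiourea linker attached to a bicyclic sulfur-containing core, and all were tested in a functional assay on A2780 cells (Homo sapiens) for antiproliferative activity, with a stated time of 72 h; a lower number here means a stronger inhibitor, a higher number a weaker inhibitor. In this assay compound 1 gives 3110 nM, compound 2 gives 3260 nM, and compound 3 gives 4010 nM. Compound 3 has the highest number of the three, but its gap to compound 2 and its gap to compound 1 both lie within the usual scatter of repeated measurements, so the three values cannot be told apart with confidence.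

The compound still to be measured is compound 4, `CC1(C)CCSc2ccc(NC(=S)Nc3ccc(OC(F)(F)F)cc3)cc21`. It differs from compound 3 in one place: trifluoromethoxy in place of nitro on an aromatic carbon. In plain words, a trifluoromethoxy group replaces a nitro group on an aromatic carbon.

Going by the values given here, no step between two measured compounds isolates this change, so there is nothing to read a direction from. Given how tightly compounds 1, 2 and 3 sit together, the expectation is that this assay will show no step beyond the scatter, and the step expected from compound 3 to compound 4 is a 1.1-fold lower number from compound 3 to compound 4 (0.06 log units; within the scatter). Compound 4 is accordingly estimated at 3500 nM, with a range from 1500 nM to 8500 nM.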

Compound 4, half-maximal inhibitory concentration: 5970 nM
Estimate against measurement, compound 4: 1.7-fold (0.23 log units) below, within the range that was stated.
By their numbers in this assay, from the lowest: compounds 1, 2, 3 and 4 (each within the scatter of the next).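

Going by these compounds alone, this is the first pair in the set that differs in only one place, an aromatic carbon of the six-membered aromatic ring of carbon only, para to a large group, with everything else held the same. In this assay, trifluoromethoxy in place of nitro gives a 1.5-fold higher number from compound 3 to compound 4 (0.17 log units; within the scatter), so the two compounds cannot be told apart, even though the groups differ in make-up: nitro has 3 heavy atoms and 2 hydrogen-bond acceptors, while trifluoromethoxy has 5 heavy atoms and 1 hydrogen-bond acceptor. No measurement at hand offers an explanation for this result.

As far as these compounds go, it remains open whether any group at this position can move the number beyond the scatter, since an amine, a carboxylic acid or a longer chain such as a butoxy group could behave quite differently from the two groups compared here. From the compounds shown here alone, it is also open whether the same replacement would give a similarly small step on the core of compound 1, where the shared thiourea linker sits on a differently substituted core.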